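The compounds below may be only part of what the source reports. "The series", "measured", "known", "first", "only" and "open" are said of these compounds alone.

Measured compounds:
- Compound 1, `COc1cc(C)cc(-c2nn(CC#N)cc2-c2ccc(-c3cccc(C(C)=O)c3)nc2)c1`: 1340 nM
- Compound 2, `Cc1cc(O)cc(-c2nn(CC#N)cc2-c2ccnc(-c3ccc(Oc4ccccc4)cc3)c2)c1`: 1880 nM
- Compound 3, `COc1cc(C)cc(-c2nn(CC#N)cc2-c2ccnc(-c3ccc(N(C)C)cc3)c2)c1`: 204 nM

In a functional assay on OVCAR-3 cells (Homo sapiens) for inhibition, read by sulforhodamine B assay, with a stated time of 48 h (on this read-out lower numbers stand for stronger inhibition of growth and higher numbers for weaker inhibition of growth), compound 3 gives the lowest of the three numbers. Compound 1 gives 1340 nM and compound 2 gives 1880 nM, both beyond the scatter from compound 3, so compound 3 stands as the strongest grower inhibitor of this set.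

Compound 4, `Cc1cc(O)cc(-c2nn(CC#N)cc2-c2ccnc(-c3ccc(N(C)C)cc3)c2)c1`, has not yet been measured in this assay. It differs from compound 3 in one place: hydrogen in place of methyl on an oxygen on an aromatic ring. Among the measured compounds shown here, no pair of measured compounds differs in exactly this way, so the step has no direct precedent here. Compound 2 also carries the hydroxy group, but it differs from compound 3 in a second place as well, so its value alone cannot tell what the change means.

The expectation is therefore a modest step, if any, and most likely toward a somewhat higher number. The estimated step from compound 3 to compound 4 in this assay is a 1.7-fold higher number from compound 3 to compound 4 (0.23 log units; within the scatter). Compound 4 is expected to give 350 nM in this assay, within a range of 120 nM to 1000 nM.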

Compound 4, concentration for 50% growth inhibition: 1910 nM
Estimate against measurement, compound 4: 5.5-fold (0.74 log units) below; the measured number lies above the stated range.
By their numbers in this assay, from the lowest: compound 3; then compounds 1, 2 and 4 (each within the scatter of the next).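

In this assay, the change from methoxy to hydroxy on the 3-methoxy-5-methylphenyl group can now be read directly, and it is large: the loss of the methyl on that oxygen gives a 9.4-fold higher number from compound 3 to compound 4 (0.97 log units; beyond the scatter) with the dimethylamino group held constant. With the hydroxy group held constant, dimethylamino in place of phenoxy gives a 1.0-fold higher number from compound 2 to compound 4 (0.01 log units; within the scatter), so among compounds 2, 3 and 4 the dimethylamino group does not by itself bring the low number of compound 3, which appears only with the methoxy group present. Nothing measured here shows why this single methyl counts for so much.

On these data alone, it remains open whether methoxy would have the same effect alongside phenoxy. As far as these compounds go, it also remains open how a longer chain on that oxygen, such as ethoxy, or an amine in place of the hydroxy group would read.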